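Amide tail variation on a shared core for vitamin D3 receptor agonism

The source may hold more compounds than are shown below. What is called first, only, known or untested is meant among the compounds shown, and "the series" means these compounds.

Compound 1 `CCn1cc(C(CC)(CC)c2ccc(C#CC(O)(CC)CC)c(C)c2)cc1C(=O)NCC(=O)OC` and compound 2 `CCn1cc(C(CC)(CC)c2ccc(C#CC(O)(CC)CC)c(C)c2)cc1C(=O)NCCCN(C)C` share a core with compound 3 `CCn1cc(C(CC)(CC)c2ccc(C#CC(O)(CC)CC)c(C)c2)cc1C(=O)NCCC(=O)O` and differ only in the group on the amide nitrogen. In an assay on cells for agonist activity at vitamin D3 receptor (Homo sapiens), read by microscopy (a higher number here means that more compound is needed for the effect, a lower number that less compound is needed), compound 1 gives 288 nM. In this assay compound 2 gives 142 nM, a step of a 2.0-fold lower number from compound 1 to compound 2 (0.31 log units; beyond the scatter). For compound 3 this assay reports only a limit, > 50 nM, so its place among the numbers is not fixed. The steps a step that the limit leaves unreadable from compound 1 to compound 3 and a step that the limit leaves unreadable from compound 2 to compound 3 therefore tell nothing of size. Compound 4 `CCn1cc(C(CC)(CC)c2ccc(C#CC(O)(CC)CC)c(C)c2)cc1C(=O)N[C@@H](C)CO` differs from compound 3 by 1-(hydroxymethyl)ethyl in place of 2-carboxyethyl on an amide-type nitrogen. Going by the values given here, no measured step covers a hydroxyl-bearing tail; the only readable step, that from compound 1 to compound 2, was modest, so a change of similar or smaller size in this assay is expected, with no readable direction from compound 3. Compound 4 is expected to give about 200 nM in this assay, between 60 nM and 700 nM, which corresponds to an estimated step that the limit leaves unreadable from compound 3 to compound 4.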

Compound 4, half-maximal effective concentration: 7.33 nM
Compound 4: middle estimate off by 27-fold (1.44 log units), on the high side; measured number outside the range, below it.
By their numbers in this assay, from the lowest: compound 4; then compound 2; then compound 1.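

On an amide-type nitrogen whose other neighbour is the carbonyl carbon, the 1-(hydroxymethyl)ethyl tail reaches a range in this assay that the earlier tails did not, with a 19-fold lower number from compound 2 to compound 4 (1.29 log units; beyond the scatter) and a 39-fold lower number from compound 1 to compound 4 (1.59 log units; beyond the scatter), both large, whereas the earlier readable change was only a 2.0-fold lower number from compound 1 to compound 2 (0.31 log units; beyond the scatter). Going by these compounds, replacing the 2-carboxyethyl tail gives an at least 6.8-fold lower number from compound 3 to compound 4 (0.83 log units; beyond the scatter), so this change is also beyond the scatter, though its full size stays unknown. For compound 3 the figure is a limit and not a number, and its steps from compound 1 and compound 2 cannot be read: the limit of > 50 nM in this assay, at which 1 of the 4 values shown sits.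

On these data alone, it remains open whether the hydroxyl group, the branch or the defined stereocentre of the 1-(hydroxymethyl)ethyl tail goes with the lower number. As far as these compounds go, how a straight 2-hydroxyethyl chain, the other stereoisomer of this tail or a longer hydroxyalkyl chain would read in this assay is also open.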